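A Hydroxyphenyl Variant on the Shared Core

The source may report more compounds than this note shows. Statements on the series, on what has been measured and on what is new or still open speak of the compounds shown alone.

Compound 1 `COc1ccc(-c2ccc3ncn(-c4cc(OC)c(OC)c(OC)c4)c3c2)cc1F` holds the lowest of the two numbers in a functional assay on A549 cells (Homo sapiens) for antiproliferative activity, read by MTT assay, with a stated time of 72 h (a higher number here means a weaker inhibitor, a lower number a stronger inhibitor), giving 1430 nM. Compound 2 `COc1cc(-n2cnc3ccc(-c4ccc([N+](=O)[O-])cc4)cc32)cc(OC)c1OC` gives 8940 nM in this assay, and the step of a 6.3-fold higher number from compound 1 to compound 2 (0.80 log units; beyond the scatter) shows that exchanging the pendant aryl group on the shared core can move the number well beyond the scatter. Compound 3 `COc1cc(-n2cnc3ccc(-c4cccc(O)c4)cc32)cc(OC)c1OC` carries 3-hydroxyphenyl in place of 3-fluoro-4-methoxyphenyl on an aromatic carbon. Within the data shown here, no measured step contains this exact exchange; the step from compound 1 to compound 2 only indicates that such replacements can weaken inhibition. Compound 3 is therefore expected to show a modest rise, a 1.7-fold higher number from compound 1 to compound 3 (0.24 log units; within the scatter), with an estimate of 2500 nM and a range from 700 nM to 9000 nM.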

Compound 3, half-maximal inhibitory concentration: 250 nM
Beside the measured number, compound 3's estimate is 10-fold (1.00 log units) above it, and the stated range ends above it.
By their numbers in this assay, from the lowest: compound 3; then compound 1; then compound 2.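

In this assay the earlier pair showed only a loss on leaving 3-fluoro-4-methoxyphenyl, whereas 3-hydroxyphenyl gives a 5.7-fold lower number from compound 1 to compound 3 (0.76 log units; beyond the scatter) and shows that this position also allows a gain. Against 4-nitrophenyl, the same group gives a 36-fold lower number from compound 2 to compound 3 (1.55 log units; beyond the scatter) and spans the widest gap among the three compounds. Nothing measured here accounts for the gain. The exchange in compound 3 removes the fluorine and the methoxy group together, and the compounds shown do not separate their parts from the entering hydroxyl. Going by these compounds, how an amine or a carboxylic acid on this phenyl ring would fare remains open.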